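The source may report more compounds than this note shows. Statements on the series, on what has been measured and on what is new or still open speak of the compounds shown alone.

Measured compounds:
Compound 1 `CN1CCN(c2ccc(C3=NN(S(C)(=O)=O)C(c4ccc(N(C)C)cc4)C3)cc2)CC1`: 0.6%
Compound 2 `CN1CCN(c2ccc(C3=NN(S(=O)(=O)c4ccc(C#N)cc4)C(c4ccc(N(C)C)cc4)C3)cc2)CC1`: 99.8%

In a functional assay on MDA-MB-231 cells (Homo sapiens) for inhibition, read by sulforhodamine B assay, tested at 10 uM (on this read-out lower numbers stand for less inhibition and higher numbers for more inhibition at the one concentration tested (going by the name of the read-out)), compound 2 gives 99.8%, the higher of the two numbers, while compound 1 gives 0.6%. Among the compounds with values here, the one measured step, a number 99.2 percentage points higher from compound 1 to compound 2 (beyond the scatter), shows that replacing the methyl on the sulfonyl sulfur with a 4-cyanophenyl moves the number from the bottom to the top of the measured range in this assay.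

Compound 3 `CN1CCN(c2ccc(C3=NN(S(=O)(=O)c4ccc(OC(F)(F)F)cc4)C(c4ccc(N(C)C)cc4)C3)cc2)CC1` keeps the shared core and the sulfonyl-bound aromatic ring of compound 2 and differs only as follows: trifluoromethoxy in place of cyano on an aromatic carbon. Within the data shown here, no measured step swaps one group for another on that ring, so the step from compound 2 to compound 3 has no direct precedent. The aromatic ring on the sulfonyl sulfur, which the step of a number 99.2 percentage points higher from compound 1 to compound 2 (beyond the scatter) shows matters, is retained. Compound 3 is therefore expected to stay high, with a modest downward step of a number 11.8 percentage points lower from compound 2 to compound 3 (beyond the scatter) in this assay. The estimate for compound 3 is 88%, in the range 45% to 100%.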

Compound 3, a percentage reported as inhibition, at one concentration (the size of the read-out at that concentration, not a potency): 10.6%
The estimate for compound 3 lay 77.4 percentage points above the measured number; measured number outside the range, below it.
By their numbers in this assay, from the lowest: compounds 1 and 3 (each within the scatter of the next); then compound 2.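

The aromatic ring on the sulfonyl sulfur is not enough by itself: with that ring kept, trifluoromethoxy in place of cyano gives a number 89.2 percentage points lower from compound 2 to compound 3 (beyond the scatter) in this assay and so, at this position, the result depends on the group the ring carries. Putting 4-(trifluoromethoxy)phenyl in place of the methyl gives a number 10 percentage points higher from compound 1 to compound 3 (within the scatter) and so, of the two rings shown, only 4-cyanophenyl brings the large gain over methyl. Nothing available here explains why these two groups part so sharply.

As far as these compounds go, it remains open whether the high number is particular to cyano or would also appear with another group at this place, such as an amine, a carboxylic acid or a methoxy group. From the compounds shown here alone, it is also open whether an unsubstituted phenyl ring on the sulfur would sit nearer compound 2 or compound 3.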